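The source may report more compounds than this note shows. Statements on the series, on what has been measured and on what is new or still open speak of the compounds shown alone.

Measured in a physicochemical assay for lipophilicity, at pH 7.4; a lower number here means a more polar compound, a higher number a more lipophilic compound:
- compound 1 `CNC(=O)c1cc(C(=O)NC2CC2)cc2c1OC[C@H]2c1cccc2[nH]ccc12`: 3.5
- compound 2 `CNC(=O)c1cc(C(=O)N[C@H]2[C@@H]3COC[C@@H]32)cc2c1OC[C@H]2c1cccc2[nH]ccc12`: 3.1
- compound 3 `CNC(=O)c1cc(C(=O)NCCC[C@H]2OC[C@H](N)CO2)cc2c1O[C@H](CF)[C@H]2c1ccccc1`: 2.9

Of these three, compound 1 stands highest, at 3.5. Compound 4 `CNC(=O)c1cc(C(=O)NC2CC2)cc2c1OC[C@H]2c1ccc(F)cc1` is not yet measured. It keeps the core of compound 1 but carries 4-fluorophenyl in place of 1H-indol-4-yl on a saturated ring carbon. Within the data shown here, the one measured step, a number 0.40 log units lower from compound 1 to compound 2 (beyond the scatter), is modest and lies on an amide-type nitrogen, so it bears on this exchange only indirectly. Among the measured compounds shown here, no measured step covers this place. In this assay the expected step, a number 0.10 log units lower from compound 1 to compound 4 (within the scatter), is therefore a slight fall that stays within the scatter. For compound 4 the estimated value is 3.4, with an expected range from 3 to 3.8.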

Compound 4, distribution coefficient: 3.8
Estimate against measurement, compound 4: 0.40 log units below; the measured number falls inside the stated range.
By their numbers in this assay, from the lowest: compounds 3 and 2 (each within the scatter of the next); then compounds 1 and 4 (each within the scatter of the next).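

Among these compounds, on the saturated ring carbon two ring bonds from the ring oxygen, exchanging 1H-indol-4-yl for 4-fluorophenyl gives in this assay a number 0.30 log units higher from compound 1 to compound 4 (within the scatter) and is the first step measured at this place. The leaving group has a five-membered aromatic ring and a hydrogen-bond donor that the entering group lacks, yet the two numbers stay within the scatter. No measured evidence accounts for this result.

Going by these compounds, whether a pyridine ring or an aminomethyl group at this carbon would also stay within the scatter remains open. So does whether this exchange reads the same with the amide-nitrogen group of compound 2.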